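A few compounds are considered here, and "the series" means these few. Any claim that something is new, unique, unknown or untested is made for them only; others in the source may bear on it.

Measured compounds:
- compound 1 `CC(C)(C)OC(=O)NCCNCC(=O)Nc1c[nH]c(=O)[nH]c1=O` — 50000 nM
- compound 2 `Nc1cn(COC(CO)CO)c(=O)[nH]c1=O` — > 100000 nM

In a functional assay on MIA PaCa-2 cells (Homo sapiens) for inhibition, read by MTT assay, with a stated time of 72 h (a lower number here means a stronger inhibitor, a higher number a weaker inhibitor), compound 1 gives 50000 nM. For compound 2 the figure > 100000 nM is a limit of this assay and not a number. Compound 2 therefore stands at the limit of > 100000 nM in this assay, at which 1 of the 2 values shown sits, the weaker end of what has been recorded in this assay. Among the measured compounds shown here, the two measured compounds differ in more than one place, so no single step between them is available.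

Compound 3 `O=c1[nH]c(=O)n(COC(CO)CO)cc1O` differs from compound 2 by hydroxy in place of amino on an aromatic carbon. For the measured compounds named here, no measured step speaks to this change, so no shift beyond the usual scatter is expected in this assay, in either direction. Compound 3 is expected to remain at the limit, estimated at 150000 nM with a range from 50000 nM to 500000 nM. The step that the limit leaves unreadable from compound 2 to compound 3 is the expected consequence.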

Compound 3, half-maximal inhibitory concentration: > 100000 nM
Compound 3: no number, only a limit; the forecaster's own chance of this, stated with the estimate: 80%; the middle value is on the limit's open side.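

Compound 2 and compound 3 both stand at a limit of this assay and not at a number, so no step can be read between them. The compounds shown leave open whether hydroxy in place of amino on an aromatic carbon changes the value in this assay at all.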